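Replacing 2,4-difluorophenyl with 4-methoxyphenyl: expectations for compound 3

This account rests on a few compounds, and the source may have more. Where it says the series, first, only, none or still open, it means among the compounds named here.

In a functional assay on MDA-MB-231 cells (Homo sapiens) for inhibition, read by MTT assay, with a stated time of 5 days (on this read-out higher numbers stand for weaker inhibition and lower numbers for stronger inhibition), compound 1 (`Cc1cc(Nc2nc(NCc3cccc(Cl)c3)nc3[nH]ncc23)n[nH]1`) gives 6860 nM, and compound 2 (`Cc1cc(Nc2nc(NCc3ccc(F)cc3F)nc3[nH]ncc23)n[nH]1`) gives 2670 nM. Going by the values given here, compound 2 therefore holds the lower of the two numbers measured so far, and so the stronger inhibition of the pair. Compound 3 (`COc1ccc(CNc2nc(Nc3cc(C)[nH]n3)c3cn[nH]c3n2)cc1`) keeps the shared core and differs from compound 2 in one place: 4-methoxyphenyl in place of 2,4-difluorophenyl on a saturated chain carbon bound to a nitrogen on an aromatic ring. Among the compounds with values here, only one measured step bears on this change: a 2.6-fold lower number from compound 1 to compound 2 (0.41 log units; beyond the scatter). That modest step replaced 3-chlorophenyl with 2,4-difluorophenyl at the same place, and it gives a rough idea of how far a change there can move the number. Within the data shown here, no measured compound carries 4-methoxyphenyl, so the data do not settle the direction. Among the measured compounds shown here, with only two values, a small move back toward compound 1, at 6860 nM, seems the more likely outcome, though this is a cautious expectation and not a trend. The expected step is a 1.5-fold higher number from compound 2 to compound 3 (0.18 log units; within the scatter). For compound 3, the estimated value is 4000 nM, with an expected range of 1500 nM to 10000 nM.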

Compound 3, half-maximal inhibitory concentration: 1320 nM
Compound 3: middle estimate off by 3.0-fold (0.48 log units), on the high side; measured number below the stated range.
By their numbers in this assay, from the lowest: compound 3; then compound 2; then compound 1.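

The new result shows that this position does not depend on a halogen on the ring: among the three compounds, the lowest number in this assay comes with 4-methoxyphenyl, which carries no fluorine or chlorine. The change from 2,4-difluorophenyl to 4-methoxyphenyl gives a 2.0-fold lower number from compound 2 to compound 3 (0.31 log units; beyond the scatter), and the change from 3-chlorophenyl gives a 5.2-fold lower number from compound 1 to compound 3 (0.72 log units; beyond the scatter), so both steps run the same way and compound 3 is the strongest inhibitor of the three on this read-out. Nothing available explains why the number moves this way.

On these data alone, what remains open is whether the improvement belongs to the methoxy group itself or simply to the loss of the halogens, a question that an unsubstituted phenyl ring at the same place could help to answer. As far as these compounds go, it is also open how far this position can be pushed with other groups, such as a hydroxyl or an ethoxy on the ring, a dimethylamine, or a longer chain between the ring and the nitrogen, and whether any of these would continue the same direction.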